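Sulfonyl series, serotonin-6 antagonism: towards compound 4

This account rests on a few compounds, and the source may have more. Where it says the series, first, only, none or still open, it means among the compounds named here.

compound 1 `CSc1nn2cccnc2c1S(=O)(=O)c1ccccc1`: 115 nM
compound 2 `CSc1nn2cccnc2c1S(=O)(=O)c1cccc(Cl)c1`: 15.1 nM
compound 3 `CSc1nn2cccnc2c1S(=O)(=O)c1ccc(F)cc1`: 132 nM

In a functional assay on HEK293 cells for antagonist activity at 5-hydroxytryptamine receptor 6 (Homo sapiens), read by cAMP accumulation, with a stated time of 2 h (a higher number here means a weaker inhibitor, a lower number a stronger inhibitor), compound 1 gives 115 nM, the second highest of the three numbers. Among the measured compounds shown here, compound 3 sits within the scatter of it (a 1.1-fold higher number from compound 1 to compound 3 (0.06 log units; within the scatter)), and the one step beyond the scatter is a 7.6-fold lower number from compound 1 to compound 2 (0.88 log units; beyond the scatter). The third step, an 8.7-fold higher number from compound 2 to compound 3 (0.94 log units; beyond the scatter), likewise concerns only the phenyl on the sulfonyl sulfur.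

Compound 4 `CNc1nn2cccnc2c1S(=O)(=O)c1ccccc1` differs from compound 1 by methylamino in place of methylsulfanyl on an aromatic carbon. For the measured compounds named here, none of the three measured steps touches this position, so no measured step bears on the change, and the expectation rests on compound 1 alone. The step of a 1.2-fold higher number from compound 1 to compound 4 (0.09 log units; within the scatter) is therefore expected to stay within the scatter, with a wide range. Compound 4 is estimated at 140 nM (range 35 nM to 600 nM) in this assay.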

Compound 4, inhibition constant: 3.89 nM
Compound 4: middle estimate off by 36-fold (1.56 log units), on the high side, outside the stated range (below it).
By their numbers in this assay, from the lowest: compound 4; then compound 2; then compounds 1 and 3 (each within the scatter of the next).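

Exchanging methylsulfanyl for methylamino gives a 30-fold lower number from compound 1 to compound 4 (1.47 log units; beyond the scatter) in this assay and so shows that this position, on the five-membered aromatic ring and next to the ring nitrogen, strongly affects the number. The exchange keeps the heavy-atom count and adds one hydrogen-bond donor, and its step is larger than any printed for the phenyl on the sulfonyl sulfur. Nothing at hand accounts for the step.

Open, on these data alone, is how an unsubstituted amine, dimethylamino or ethylamino would compare at this position. Also open, as far as these compounds go, is whether 3-chlorophenyl on the sulfonyl sulfur would lower the number further alongside methylamino.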